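The source may report more compounds than this note shows. Statements on the series, on what has been measured and on what is new or still open speak of the compounds shown alone.

Of the compounds shown here, three have been measured so far in a physicochemical assay for lipophilicity, measured as octanol-water partition; a lower number here means a more polar compound, a higher number a more lipophilic compound. Compound 1 `CCCCCCCCc1cn(C/C=C(/C)CCC=C(C)C)nn1` gives 6.92, the second highest of the three numbers. Compound 2 `CCCCCc1cn(C/C=C(/C)CC/C=C(\C)CCC=C(C)C)nn1` gives 7.5, and its gap to compound 1 lies beyond the scatter. Compound 3 `CCCCCc1cn(CC=C(C)C)nn1` lies much lower at 3.46, also beyond the scatter from compound 1.

Compound 4 `CCCc1cn(C/C=C(/C)CCC=C(C)C)nn1` has not yet been measured. It differs from compound 1 in one place: hydrogen in place of pentyl on a saturated chain carbon, three bonds along the chain from an aromatic carbon. Put simply, hydrogen stands in place of pentyl on a saturated chain carbon, three bonds along the chain from an aromatic carbon, so that chain becomes shorter while everything else in compound 1 stays the same.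

For the measured compounds named here, no measured pair differs in just one place, so there is no direct precedent for the size of this change. A clear fall in this assay is still expected, well beyond the scatter, and compound 4 is expected to land between compound 3 at 3.46 and compound 1 at 6.92. The estimated step is a number 2.42 log units lower from compound 1 to compound 4 (beyond the scatter). For compound 4 the expected value is 4.5, with an estimated range from 4 to 5.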

Compound 4, partition coefficient: 4.05
Beside the measured number, compound 4's estimate is 0.45 log units above it, within the range that was stated.
By their numbers in this assay, from the lowest: compound 3; then compound 4; then compound 1; then compound 2.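

In this assay, for the compounds shown here, putting hydrogen in place of pentyl on a saturated chain carbon, three bonds along the chain from an aromatic carbon, gives a number 2.87 log units lower from compound 1 to compound 4 (beyond the scatter) and is the first step in this set that changes one place alone. Everything else in compound 1 stays the same in compound 4, so the whole of this large step belongs to that one change, and the number at this position clearly responds to what sits on the chain. No separate measurement here bears on why the step has this size.

A single step cannot tell whether the number falls evenly as the chain is shortened or mostly over part of its length, and a chain ending in a butyl or propyl group at this same carbon would help to settle that. It also leaves open what an amine, a hydroxyl group or a carboxylic acid would do in place of pentyl here, and whether the same change gives a step of similar size when the other chain on the core is longer or shorter.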